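Dropping the chloro from compound 1: cytotoxicity notes

This account rests on a few compounds, and the source may have more. Where it says the series, first, only, none or still open, it means among the compounds named here.

Measured so far in an ADME assay on MDBK cells (Bos taurus) for cytotoxicity, read by MTT assay, with a stated time of 96 h; on this read-out higher numbers stand for lower toxicity in this test and lower numbers for higher toxicity in this test:
- compound 1 `Clc1cccc(/N=N/N2CCCC2)c1`: > 100000 nM
- compound 2 `CCOC(=O)N1CCN(/N=N/c2ccccc2)CC1`: > 100000 nM

Both entries are limits of the assay and not numbers. Compound 1 gives no number of its own and stands at the limit of > 100000 nM in this assay, at which 2 of the 2 values shown sit. Compound 3 `c1ccc(/N=N/N2CCCC2)cc1` is the next to be read. It has hydrogen in place of chloro on an aromatic carbon. Among the compounds with values here, no measured pair isolates this change, so there is no direct precedent for its size. No step beyond the usual scatter is expected in this assay, and neither direction is favoured. The expectation rests on compound 1 at > 100000 nM, which is a limit. The estimate amounts to a number no higher from compound 1 to compound 3 (the limit leaves the size open), and a further limit reading is the likeliest result. Compound 3 is estimated at 100000 nM, with an expected range of 40000 nM to 200000 nM.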

Compound 3, half-maximal cytotoxic concentration: > 100000 nM
Compound 3: only a limit was reported (the forecaster's own chance of this, stated with the estimate: 80%); the middle value lies on the limit itself.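

Compound 1 and compound 3 are both limits in this assay, so no step can be read for hydrogen in place of chloro on an aromatic carbon: the limit of > 100000 nM in this assay, at which 3 of the 3 values shown sit.

The compounds shown leave open whether this change alters the half-maximal cytotoxic concentration at all, since none gives a number in this assay.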